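The compounds below may be only part of what the source reports. "The series", "measured", "known", "first", "only" and "open" are said of these compounds alone.

Measured so far in a functional assay on K562 cells (Homo sapiens) for cytotoxicity, read by sulforhodamine B assay; on this read-out higher numbers stand for lower toxicity in this test and lower numbers for higher toxicity in this test:
- compound 1 `CC1=CC[C@@H]([C@@](C)(O)CCCC(C)(C)NC(=S)N/N=C\c2ccc(C)cc2)CC1`: > 100000 nM
- compound 2 `COc1ccc(/C=N\NC(=S)NC(C)(C)CCC[C@](C)(O)[C@@H]2CC=C(C)CC2)cc1`: > 100000 nM
- compound 3 `CC1=CC[C@@H]([C@@](C)(O)CCCC(C)(C)NC(=S)N/N=C\c2ccccc2[N+](=O)[O-])CC1`: > 100000 nM

Each of these entries is a limit of the assay and not a number. The whole set therefore rests on a single mark, (the limit of > 100000 nM in this assay, at which 3 of the 3 values shown sit). Compound 3 has no exact position, and it cannot be ranked against compound 1 or compound 2.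

Compound 4 `CC1=CC[C@@H]([C@@](C)(O)CCCC(C)(C)NC(=S)N/N=C\c2ccc([N+](=O)[O-])cc2)CC1` changes compound 3 in one place: 4-nitrophenyl in place of 2-nitrophenyl on a carbon with a double bond to nitrogen, (4-nitrophenyl in place of 2-nitrophenyl on a carbon with a double bond to nitrogen). The two have the same atoms, joined differently.

The closest evidence comes from changes to this same aromatic group. These are a step that the two limits leave unreadable from compound 1 to compound 3, a step that the two limits leave unreadable from compound 2 to compound 3 and a step that the two limits leave unreadable from compound 1 to compound 2. None of the three has a readable size, so they show no direction and no measure of how much this group matters. They do show that all three aromatic groups tried so far left the read-out at the limit, and so no change beyond the scatter is expected. The expected step is a number no higher from compound 3 to compound 4 (the limit leaves the size open). Compound 4 is estimated at 100000 nM, with an expected range from 40000 nM to 200000 nM, and it will most likely be reported as a limit again.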

Compound 4, concentration lethal to 50% of the cells: 45500 nM
The estimate for compound 4 lay 2.2-fold (0.34 log units) above the measured number; the range from low to high includes it.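

In this assay, 4-nitrophenyl in place of 2-nitrophenyl gives an at least 2.1-fold lower number from compound 3 to compound 4 (0.34 log units; beyond the scatter), so two groups with the same atoms, joined differently, can be told apart here, and a change at this aromatic group can bring the read-out off the limit and towards higher toxicity in this test. The other two comparisons agree: nitro in place of methoxy gives an at least 2.1-fold lower number from compound 2 to compound 4 (0.34 log units; beyond the scatter), and nitro in place of methyl gives an at least 2.1-fold lower number from compound 1 to compound 4 (0.34 log units; beyond the scatter), yet a nitro group alone does not settle the matter, since compound 3 carries one and stays at the limit. The steps among compounds 1, 2 and 3 still cannot be read, and compound 4 alone has an exact number: the limit of > 100000 nM in this assay, at which 3 of the 4 values shown sit.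

From the compounds shown here alone, how far compounds 1, 2 and 3 lie from compound 4 stays unknown, since each of those three is only bounded on one side. Also open, going by these compounds, is whether a nitrile, a trifluoromethyl or a carboxylic acid in place of the nitro group of 4-nitrophenyl would give a number like that of compound 4, or one back at the limit.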